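The compounds below may be only part of what the source reports. "The series", "measured", "known", "first", "only" and "open" are said of these compounds alone.

Working notes on the series. Of the compounds shown here, two sharing the core have been measured. Compound 1 `CN1CCC(C(=O)N2Cc3c(NC(=O)NCc4ccccc4)n[nH]c3C2(C)C)CC1` carries a benzylcarbamoyl group on the shared core; in a functional assay on A2780 cells (Homo sapiens) for antiproliferative activity, read by fluorescence, with a stated time of 72 h (a lower number here means a stronger inhibitor, a higher number a weaker inhibitor), compound 1 gives 2680 nM. Compound 2 `CN(C)CC(=O)Nc1n[nH]c2c1CN(C(=O)C(C)(C)C)C2(C)C` gives 580 nM in this assay, so compound 1 stands with the higher of the two numbers, and the gap between them is beyond the scatter. The two compounds differ in more than one place, so no single step can be read from that pair.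

Compound 3 `CCCNC(=O)Nc1n[nH]c2c1CN(C(=O)C1CCN(C)CC1)C2(C)C` has not yet been measured. It differs from compound 1 in one place: ethyl in place of phenyl on a saturated chain carbon bound to an amide-type nitrogen. Cut one bond further out, the change reads benzylcarbamoyl to propylcarbamoyl. For the measured compounds named here, no measured pair in the set follows this change, and compound 2 offers no read-across to it. With nothing measured to point either way, the step is expected to be a 1.1-fold lower number from compound 1 to compound 3 (0.03 log units; within the scatter), with no clear direction beyond the scatter. In this assay compound 3 is accordingly expected to give around 2500 nM, within a range of 900 nM to 7000 nM.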

Compound 3, half-maximal inhibitory concentration: 650 nM
Compound 3: the middle estimate sits 3.8-fold (0.59 log units) above what was measured; measured number below the stated range.
By their numbers in this assay, from the lowest: compounds 2 and 3 (each within the scatter of the next); then compound 1.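

For the compounds shown here, the first step that can be read at a single place falls on the group carried by the shared core: with ethyl in place of phenyl on a saturated chain carbon bound to an amide-type nitrogen, that is benzylcarbamoyl to propylcarbamoyl, this assay shows a 4.1-fold lower number from compound 1 to compound 3 (0.62 log units; beyond the scatter) and this lies beyond the scatter. This position therefore responds to what the chain carries, and within this pair the six-membered aromatic ring of carbon is not required for the lower number, since the ring-free propylcarbamoyl group gives it. Nothing available accounts for the size or direction of this step.

A single step changes ring and chain together, so the compounds shown leave open whether the lower number follows from losing the aromatic ring or from the change in the group as a whole. Cyclohexyl in place of phenyl would separate the two, while a longer chain such as pentyl, or a chain ending in an amine or a carboxylic acid, would show how far this position tolerates further change.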